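The compounds below may be only part of what the source reports. "The series", "measured", "known", "first", "only" and "open" are said of these compounds alone.

Compound 1 `COc1cc(OCCOCCNC2CCCC2)ccc1OCc1ccccc1`: 44600 nM
Compound 2 `O=[N+]([O-])c1cccc(COc2ccc(OCCOCCNC3CCCC3)cc2)c1`: 15400 nM

Of the compounds shown here, two have been measured so far, and they share a common core while differing in one group only. In a functional assay on SK-OV-3 cells (Homo sapiens) for inhibition, read by CCK-8 assay, with a stated time of 70 h (a lower number here means a stronger inhibitor, a higher number a weaker inhibitor), compound 1 gives 44600 nM, while compound 2 gives 15400 nM. Compound 2 therefore has the lower of the two numbers, and its gap to compound 1 lies beyond the usual scatter of repeated measurements, so compound 2 is the stronger inhibitor of the pair.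

Compound 3 `COC(=O)c1cccc(COc2ccc(OCCOCCNC3CCCC3)cc2)c1` has not yet been measured. It differs from compound 2 in one place: methoxycarbonyl in place of nitro on an aromatic carbon. Among the measured compounds shown here, no measured pair shows what this particular change does, so there is nothing to lean on beyond the value of compound 2 itself. A small step is expected, if any, likely toward a somewhat higher number but possibly staying within the scatter; the expected step is a 1.4-fold higher number from compound 2 to compound 3 (0.15 log units; within the scatter). Compound 3 is estimated at 22000 nM, with a range from 7000 nM to 70000 nM.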

Compound 3, half-maximal inhibitory concentration: 45500 nM
Compound 3: the middle estimate sits 2.1-fold (0.32 log units) below what was measured; measured number inside the range.
By their numbers in this assay, from the lowest: compound 2; then compounds 1 and 3 (each within the scatter of the next).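

Placing methoxycarbonyl where compound 2 carries nitro gives a 3.0-fold higher number from compound 2 to compound 3 (0.47 log units; beyond the scatter) in this assay, so compound 3 is the weaker inhibitor of this pair. Among the compounds shown here, this is the first direct reading at this place on the aromatic ring, and it shows that the choice of group there changes the result, even though both groups have the same count of hydrogen-bond acceptors and donors and neither has a net charge. No evidence is available to explain this step.

This single step cannot show whether nitro is unusually good here or methoxycarbonyl unusually poor: a nitrile, an amine or a carboxylic acid on the same aromatic carbon would help separate the two readings. Also open, on these data alone, is whether ethoxycarbonyl, with its longer chain, would read like methoxycarbonyl.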